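Swapping Cyclobutyl for Phenyl on the Ether Side Chain

The source may report more compounds than this note shows. Statements on the series, on what has been measured and on what is new or still open speak of the compounds shown alone.

Among the compounds with values here, compound 3 `O=C(NCc1ccc(C(F)(F)F)nc1OCC1CCC1)Nc1cccc2c(=O)[nH]ccc12` gives 63.2 nM in an assay on CHO cells for agonist activity at transient receptor potential cation channel subfamily V member 1 (Homo sapiens) (on this read-out lower numbers stand for an effect already at smaller amounts and higher numbers for an effect only at larger amounts of compound), the second highest of the three numbers known so far. Compound 2 `CC(C)COc1nc(C(F)(F)F)ccc1CNC(=O)Nc1cccc2c(=O)[nH]ccc12` gives 78.7 nM, and the step of a 1.2-fold lower number from compound 2 to compound 3 (0.10 log units; within the scatter) lies within the scatter. Compound 1 `O=C(NCc1ccc(C(F)(F)F)nc1N1CCCCC1)Nc1cccc2c(=O)[nH]ccc12` gives 13.2 nM, and the step of a 4.8-fold higher number from compound 1 to compound 3 (0.68 log units; beyond the scatter) is modest. Compound 4 `O=C(NCc1ccc(C(F)(F)F)nc1OCc1ccccc1)Nc1cccc2c(=O)[nH]ccc12` differs from compound 3 by phenyl in place of cyclobutyl on a saturated chain carbon bound to an oxygen on an aromatic ring. Of the known steps, only a 1.2-fold lower number from compound 2 to compound 3 (0.10 log units; within the scatter) changes that same carbon, and it stayed within the scatter; the steps of a 6.0-fold higher number from compound 1 to compound 2 (0.78 log units; beyond the scatter) and a 4.8-fold higher number from compound 1 to compound 3 (0.68 log units; beyond the scatter) exchange a different group and say little here. A small step is therefore expected, with the estimate meaning a 1.1-fold lower number from compound 3 to compound 4 (0.02 log units; within the scatter). For compound 4 the estimated value is 60 nM, with a range from 20 nM to 200 nM.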

Compound 4, half-maximal effective concentration: 78.6 nM
Beside the measured number, compound 4's estimate is 1.3-fold (0.12 log units) below it; the range from low to high includes it.
By their numbers in this assay, from the lowest: compound 1; then compounds 3, 4 and 2 (each within the scatter of the next).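

On this saturated chain carbon, swapping in phenyl, an aromatic six-membered ring, leaves the number within the scatter of both cyclobutyl (a 1.2-fold higher number from compound 3 to compound 4 (0.09 log units; within the scatter)) and isopropyl (a 1.0-fold lower number from compound 2 to compound 4 (0.00 log units; within the scatter)), so these three groups cannot be told apart here. The benzyloxy group also stays clearly apart from piperidin-1-yl on the aromatic carbon (a 6.0-fold higher number from compound 1 to compound 4 (0.77 log units; beyond the scatter)), as the two other ether compounds do. Nothing measured here explains why these groups read alike. Still open, as far as these compounds go, is whether an amine or a carboxylic acid on that chain carbon would stay in this range, and whether morpholine in place of piperidin-1-yl would keep the lower number of compound 1.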